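This account rests on a few compounds, and the source may have more. Where it says the series, first, only, none or still open, it means among the compounds named here.

Compounds 1, 2 and 3 share one core and differ only in the length of a saturated chain. Compound 1 `CCCCCCNc1nc(SCc2ccc(C(F)(F)F)cc2)nc2ccccc12` gives 24300 nM in a functional assay on MCF7 cells (Homo sapiens) for cytotoxicity, read by MTT assay, with a stated time of 72 h; a lower number here means a stronger inhibitor, a higher number a weaker inhibitor. Compound 2 `CCCCCCCCNc1nc(SCc2ccc(C(F)(F)F)cc2)nc2ccccc12` gives 26100 nM in this assay, the higher of the two plain numbers, though the step of a 1.1-fold higher number from compound 1 to compound 2 (0.03 log units; within the scatter). Compound 3 `CCCCCCCCCCCCCCNc1nc(SCc2ccc(C(F)(F)F)cc2)nc2ccccc12` reaches only a limit in this assay, at > 50000 nM. From there the step of an at least 2.0-fold higher number from compound 1 to compound 3 (0.31 log units; beyond the scatter), while the step of an at least 1.9-fold higher number from compound 2 to compound 3 (0.28 log units; that floor lies within the scatter). Compound 4 `FC(F)(F)c1ccc(CSc2nc(N3CCCCC3)c3ccccc3n2)cc1` differs from compound 2 in that (piperidin-1-yl in place of octylamino on an aromatic carbon). Going by the values given here, no measured step matches this change; the chain steps show only that lengthening never gave a lower number. A step of a 1.3-fold lower number from compound 2 to compound 4 (0.12 log units; within the scatter) is expected, so compound 4 is estimated at 20000 nM, within a range from 8000 nM to 50000 nM.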

Compound 4, half-maximal inhibitory concentration: > 50000 nM
Compound 4 gave a limit, no number; the forecaster's own chance of this, stated with the estimate: 15%; middle value at least 2.5-fold (0.39 log units) away from the limit.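

Compound 4 gives no number, only a limit, and so joins compound 3: the limit of > 50000 nM in this assay, at which 2 of the 4 values shown sit. Swapping the open chain for piperidin-1-yl on this aromatic carbon gives an at least 2.0-fold higher number from compound 1 to compound 4 (0.31 log units; beyond the scatter) and an at least 1.9-fold higher number from compound 2 to compound 4 (0.28 log units; that floor lies within the scatter), so this ring brought no lower number, and only the floor of the first step is beyond the scatter. Compound 3 keeps its hydrogen-bond donor yet sits at the same limit, which goes against tying the limit to the loss of that donor. As far as these compounds go, whether a morpholine ring or a shorter chain such as butylamino would give a lower number stays open.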